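The source may hold more compounds than are shown below. What is called first, only, known or untested is meant among the compounds shown, and "the series" means these compounds.

Measured so far, in a functional assay on HT-29 cells (Homo sapiens) for cytotoxicity, read by MTT assay, with a stated time of 24 h, tested at 6.4 ug/mL; a lower number here means a weaker effect, a higher number a stronger effect of the compound at the concentration tested:
compound 1 `Cn1c(-c2ccc(NC(=O)CSc3nc4ccccc4o3)cc2)nc(-c2ccccc2)c1-c1ccccc1`: 44.9%
compound 2 `Cn1nnnc1SCC(=O)Nc1ccc(-c2nc(-c3ccccc3)c(-c3ccccc3)n2C)cc1`: 60.6%

Compound 2 stands highest of the two numbers; the nearest is compound 1, with the step of a number 15.7 percentage points higher from compound 1 to compound 2 (beyond the scatter) lying beyond the scatter. Compound 3 `Cn1c(-c2ccc(NC(=O)CSC3=NCCS3)cc2)nc(-c2ccccc2)c1-c1ccccc1` differs from compound 2 by a group of 5 heavy atoms (3 carbon, 1 nitrogen, 1 sulfur; one five-membered non-aromatic ring with 2 hetero atoms) in place of a group of 6 heavy atoms (2 carbon, 4 nitrogen; one five-membered aromatic ring with 4 hetero atoms), on a sulfur. Within the data shown here, the only step that bears on it is the one from compound 1 to compound 2, a modest gain on exchanging the group on that sulfur; it gives no direction for a non-aromatic ring there. For compound 3 the step of a number 10.6 percentage points lower from compound 2 to compound 3 (beyond the scatter) is expected to be small and of uncertain sign, so compound 3 is estimated at 50%, within 30% to 70%.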

Compound 3, a percentage reported as activity, at one concentration (the size of the read-out at that concentration, not a potency): 31%
Beside the measured number, compound 3's estimate is 19 percentage points above it, within the range that was stated.
By their numbers in this assay, from the lowest: compound 3; then compound 1; then compound 2.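

In this assay, exchanging the group on the sulfur for the non-aromatic five-membered ring gives a number 29.6 percentage points lower from compound 2 to compound 3 (beyond the scatter) and a number 13.9 percentage points lower from compound 1 to compound 3 (beyond the scatter). This position therefore responds to more than the choice between the two aromatic groups: both stand above the non-aromatic ring, so the three compounds now span a clear range. Nothing available bears on why the number falls.

Still open, going by these compounds, is whether a phenyl ring, a pyridine ring or a simple methyl on that sulfur would stand with compound 1 and compound 2 or with compound 3.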